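Bromobenzyl positional isomer within the cytotoxicity series

The source may report more compounds than this note shows. Statements on the series, on what has been measured and on what is new or still open speak of the compounds shown alone.

Compound 2 `CCOC(=O)c1cnc(N2CCN(Cc3ccc(Br)cc3)CC2)nc1Oc1c(C)cc(-c2ccc(C#N)cc2)cc1C` has been measured in an ADME assay on MT4 cells (Homo sapiens) for cytotoxicity, read by MTT assay, with a stated time of 4 days; a higher number here means that more compound is tolerated, a lower number that less compound is tolerated. Compound 2 gives > 125000 nM, which is a limit of the assay and not a number. Compound 1 `CCOC(=O)c1cnc(N2CCN(Cc3cccc(C(=O)OC)c3)CC2)nc1Oc1c(C)cc(-c2ccc(C#N)cc2)cc1C` gives > 125000 nM, likewise a limit. The step that the two limits leave unreadable from compound 1 to compound 2 cannot be sized; the limit of > 125000 nM in this assay, at which 2 of the 2 values shown sit, covers both values. Compound 3 `CCOC(=O)c1cnc(N2CCN(Cc3ccccc3Br)CC2)nc1Oc1c(C)cc(-c2ccc(C#N)cc2)cc1C` differs from compound 2 as 2-bromophenyl in place of 4-bromophenyl on a saturated chain carbon bound to an amine nitrogen in a ring. Within the data shown here, no measured step bears on this change, so no shift beyond the scatter is expected in this assay, and compound 3 is expected to remain at the limit. The estimate for compound 3 is 125000 nM (range 60000 nM to 250000 nM), an expected step of a number no higher from compound 2 to compound 3 (the limit leaves the size open).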

Compound 3, half-maximal cytotoxic concentration: > 125000 nM
Compound 3 ended at the assay's limit; the forecaster's own chance of this, stated with the estimate: 85%; the middle value sits exactly at the limit.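

No step can be read among compound 1, compound 2 and compound 3 in this assay, as each value is a limit and not a number: the limit of > 125000 nM in this assay, at which 3 of the 3 values shown sit.

Going by these compounds, whether any change on the shared core gives a readable number in this assay stays open.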